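Trifluoromethyl for nitro: working notes on the series

The compounds below may be only part of what the source reports. "The series", "measured", "known", "first", "only" and "open" are said of these compounds alone.

Measured in a functional assay on HepG2 cells (Homo sapiens) for cytotoxicity, read by spectrophotometry, with a stated time of 72 h; on this read-out higher numbers stand for weaker inhibition and lower numbers for stronger inhibition:
compound 1 `COc1ccc(-n2c(-c3cc(OC)c(OC)c(OC)c3)cccc2=O)cc1O`: 1220 nM
compound 2 `COc1ccc(-n2c(-c3cc(OC)c(OC)c(OC)c3)cccc2=O)cc1`: 5740 nM
compound 3 `COc1cc(-c2cccc(=O)n2-c2ccc([N+](=O)[O-])cc2)cc(OC)c1OC`: 941 nM

Compound 3 shares the low end of these numbers. Its nearest neighbour gives a 1.3-fold lower number from compound 1 to compound 3 (0.11 log units; within the scatter), and the furthest gives a 6.1-fold lower number from compound 2 to compound 3 (0.79 log units; beyond the scatter).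

Next in line is compound 4 `COc1cc(-c2cccc(=O)n2-c2ccc(C(F)(F)F)cc2)cc(OC)c1OC`, which carries trifluoromethyl in place of nitro on an aromatic carbon, para to a large group (trifluoromethyl in place of nitro on an aromatic carbon).

Going by the values given here, no measured step makes this exchange, and no measured compound other than this one carries trifluoromethyl. The closest evidence comes from the same aromatic carbon, where methoxy gives way to nitro in a 6.1-fold lower number from compound 2 to compound 3 (0.79 log units; beyond the scatter). That step is modest and shows that this place can move the number, but it says nothing about how nitro and trifluoromethyl compare. The step of a 4.7-fold higher number from compound 1 to compound 2 (0.67 log units; beyond the scatter) concerns a hydroxy group elsewhere and bears on this exchange only loosely. The expectation therefore stays close to compound 3 at 941 nM, with a slight lean towards a higher number and no change beyond the scatter.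

In this assay the expected step is a 1.4-fold higher number from compound 3 to compound 4 (0.14 log units; within the scatter).

For compound 4 the estimated value is 1300 nM, with an expected range from 500 nM to 3500 nM.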

Compound 4, half-maximal inhibitory concentration: 10200 nM
Beside the measured number, compound 4's estimate is 7.8-fold (0.89 log units) below it, and the stated range ends below it.
By their numbers in this assay, from the lowest: compounds 3 and 1 (each within the scatter of the next); then compounds 2 and 4 (each within the scatter of the next).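

In this assay the exchange of nitro for trifluoromethyl on this aromatic carbon is a large step (an 11-fold higher number from compound 3 to compound 4 (1.04 log units; beyond the scatter)), so this place distinguishes between these two groups, which the earlier step from methoxy to nitro could not show. Trifluoromethyl set against methoxy at the same carbon gives a 1.8-fold higher number from compound 2 to compound 4 (0.25 log units; within the scatter), so among the three groups seen here only nitro stands apart, and the low number of compound 3 goes with nitro rather than with any departure from methoxy. Nothing available here explains why nitro and trifluoromethyl part so widely at this place.

From the compounds shown here alone, whether the low number is particular to nitro remains open, since a nitrile, a carboxylic acid or an amine on this aromatic carbon would show whether any other group can match compound 3. Also open, going by these compounds, is whether the hydroxy group that separates compound 1 from compound 2 would shift the number in the same direction if added to compound 4, where trifluoromethyl replaces the methoxy of compound 2.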